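Adding ethyl to the chain of compound 1

This account rests on a few compounds, and the source may have more. Where it says the series, first, only, none or still open, it means among the compounds named here.

In an ADME assay on L929 cells (Mus musculus, culture collection number NCTC 929) for cytotoxicity, read by MTT assay, with a stated time of 72 h (a lower number here means a stronger inhibitor, a higher number a weaker inhibitor), compound 1 (`CCCCCCCCc1c(O)cc(C)oc1=O`) gives 145000 nM and compound 2 (`Cc1cc(O)c(C(=S)NC2CCCCC2)c(=O)o1`) gives 177000 nM and compound 3 (`CCCCCCCNC(=O)c1c(O)cc(C)oc1=O`) gives 187000 nM so all three stand within the scatter of one another. Compound 4 (`CCCCCCCCCCc1c(O)cc(C)oc1=O`) differs from compound 1 by ethyl in place of hydrogen on a saturated chain carbon, eight bonds along the chain from an aromatic carbon with ethyl in place of hydrogen on a saturated chain carbon, eight bonds along the chain from an aromatic carbon. Within the data shown here, no measured pair shows a change of this kind, so the expectation starts from compound 1 at 145000 nM alone. A small move toward a lower number in this assay is expected, and the estimated step of a 1.3-fold lower number from compound 1 to compound 4 (0.12 log units; within the scatter) may well stay within the scatter. For compound 4 the estimate is 110000 nM with 50000 nM to 200000 nM as the expected range.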

Compound 4, half-maximal inhibitory concentration: 56000 nM
Compound 4: middle estimate off by 2.0-fold (0.29 log units), on the high side, and the stated range covers the measured number.
By their numbers in this assay, from the lowest: compound 4; then compounds 1, 2 and 3 (each within the scatter of the next).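

Ethyl in place of hydrogen on a saturated chain carbon, eight bonds along the chain from an aromatic carbon, moves the number in this assay beyond the scatter, a 2.6-fold lower number from compound 1 to compound 4 (0.41 log units; beyond the scatter). This position therefore responds to chain extension, although the size of the step is modest. No measured evidence bears on the reason for this response.

As far as these compounds go, it remains open whether a longer chain would lower the number further or whether the trend would reverse. The effect of an amine or a carboxylic acid on the chain is also unresolved.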